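This account rests on a few compounds, and the source may have more. Where it says the series, first, only, none or still open, it means among the compounds named here.

Measured in a functional assay on SK-OV-3 cells (Homo sapiens) for inhibition, read by sulforhodamine B assay, with a stated time of 48 h; on this read-out lower numbers stand for stronger inhibition of growth and higher numbers for weaker inhibition of growth:
compound 1, `COc1cc(-c2nn(-c3cccc(NC(=O)Nc4cc(C(F)(F)F)cc(C(F)(F)F)c4)c3)cc2-c2ccncc2)ccc1Cl`, 1090 nM
compound 2, `COc1cc(-c2nn(-c3cccc(NC(=O)Nc4ccc(Cl)c(Cl)c4)c3)cc2-c2ccncc2)ccc1Cl`, 1930 nM
compound 3, `O=C(Nc1cccc(-n2cc(-c3ccncc3)c(-c3ccc(Cl)c(O)c3)n2)c1)Nc1ccc(Cl)c(Cl)c1`, 1200 nM

The three numbers sit close together. Compound 2 carries the largest of them, yet its gap to compound 3 is the step of a 1.6-fold lower number from compound 2 to compound 3 (0.21 log units; within the scatter), and its gap to compound 1 is of similar size and also within the scatter. Going by the values given here, on this read-out no measured compound stands apart from the others.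

Compound 4, `COc1cc(-c2nn(-c3cccc(NC(=O)Nc4ccc(Cl)c(C(F)(F)F)c4)c3)cc2-c2ccncc2)ccc1Cl`, is the next member. It differs from compound 2 by trifluoromethyl in place of chloro on an aromatic carbon. Among the compounds with values here, the only step recorded, from compound 2 to compound 3, concerns the other aryl ring and stayed within the scatter, so it says nothing direct about this change. Compound 1 and compound 2 differ in the same ring that changes here, though by a different substitution, and their values lie within the scatter of each other. Nothing in the series points to a move beyond the scatter in this assay for this exchange.

Compound 4 is therefore expected near 1500 nM, estimated between 700 nM and 3500 nM. The expected step from compound 2 is a 1.3-fold lower number from compound 2 to compound 4 (0.11 log units; within the scatter), which would be within the scatter.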

Compound 4, concentration for 50% growth inhibition: 1450 nM
Estimate against measurement, compound 4: 1.0-fold (0.01 log units) above; the range from low to high includes it.
By their numbers in this assay, from the lowest: compounds 1, 3, 4 and 2 (each within the scatter of the next).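

In this assay, the exchange of chloro for trifluoromethyl on the aromatic carbon ortho to a chloro group gives a 1.3-fold lower number from compound 2 to compound 4 (0.12 log units; within the scatter), the first single-place step recorded in this aryl ring, where 3,4-dichlorophenyl becomes 4-chloro-3-(trifluoromethyl)phenyl. At this position, then, a group of 4 heavy atoms can stand in place of a single chlorine with the growth read-out staying within the scatter, so this one exchange gives no handle on the read-out in this series. No measurement at hand offers an explanation for this result.

Open, on these data alone, is whether a group of another kind on this same aromatic carbon, such as a nitrile, an amine or a carboxylic acid, would also stay within the scatter of compound 2, or whether this carbon tolerates only groups resembling chloro and trifluoromethyl. Also open, as far as these compounds go, is whether the same exchange reads the same way on the core of compound 3, with its hydroxyl in place of the methoxy group of compound 2.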